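The source may report more compounds than this note shows. Statements on the series, on what has been measured and on what is new or still open speak of the compounds shown alone.

Measured in a functional assay on HCT-116 cells (Homo sapiens) for antiproliferative activity, read by MTT assay, with a stated time of 48 h; a lower number here means a stronger inhibitor, a higher number a weaker inhibitor:
Compound 1 `CCCCCC(CCO)n1cnc2c(NC)ncnc21`: > 50000 nM, a limit.
Compound 2 `CCCCCCC(CCO)n1cnc2c(NC)ncnc21`: > 50000 nM, a limit.
Compound 3 `CCCCCCCCCC(CCO)n1cnc2c(OC)ncnc21`: 2530 nM.

Among the compounds with values here, compound 3 holds the only number here, since the other two values are limits. Compound 4 `CCCCCCCCCC(CCO)n1cnc2c(NC)ncnc21` keeps the chain of compound 3 but has methylamino in place of methoxy on an aromatic carbon. Within the data shown here, the one measured step, a step that the two limits leave unreadable from compound 1 to compound 2, concerns the chain and gives no size for this change. Compound 1 and compound 2 both carry methylamino, on shorter chains, and stand at the limit of > 50000 nM in this assay, at which 2 of the 3 values shown sit. A weaker result in this assay is therefore expected, though only loosely, with an estimated 3.2-fold higher number from compound 3 to compound 4 (0.50 log units; beyond the scatter). Compound 4 is estimated at 8000 nM, with an expected range of 2000 nM to 35000 nM.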

Compound 4, half-maximal inhibitory concentration: 5410 nM
Compound 4: middle estimate off by 1.5-fold (0.17 log units), on the high side, within the range that was stated.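

With the long chain kept, methylamino in place of methoxy on this aromatic carbon now has a size in this assay: it gives a 2.1-fold higher number from compound 3 to compound 4 (0.33 log units; beyond the scatter) and still leaves a measured number. With methylamino held, the longer chain gives an at least 9.2-fold lower number from compound 2 to compound 4 (0.96 log units; beyond the scatter) and likewise an at least 9.2-fold lower number from compound 1 to compound 4 (0.96 log units; beyond the scatter) and so moves the number further than the change on the aromatic carbon does. Compound 1 and compound 2 each stand at a limit, so these two chain steps are bounds and not exact sizes: the limit of > 50000 nM in this assay, at which 2 of the 4 values shown sit.

The compounds shown leave open how an amino or a dimethylamino group on this aromatic carbon would compare with methylamino and methoxy. They also leave open whether a chain longer than that of compound 4 would lower the number further.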